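The source may hold more compounds than are shown below. What is called first, only, known or untested is meant among the compounds shown, and "the series" means these compounds.

Working notes on the series.

Compound 3 `COc1ccc(-c2cn(-c3cccc(C(=O)/C=C/c4cc(OC)c(OC)c(OC)c4)c3)c(=O)[nH]2)cc1` gives 1700 nM in a functional assay on NCI/ADR-RES cells (Homo sapiens) for inhibition; on this read-out lower numbers stand for stronger inhibition of growth and higher numbers for weaker inhibition of growth. Compound 1 `COc1cc(/C=C/C(=O)c2cccc(-n3cc(-c4ccc(Cl)cc4)[nH]c3=O)c2)cc(OC)c1OC` differs from it by chloro in place of methoxy on an aromatic carbon; in this assay compound 1 gives 2360 nM, the step being a 1.4-fold higher number from compound 3 to compound 1 (0.14 log units; within the scatter). Compound 2 `COc1ccc(-c2cn(-c3cccc(C(=O)/C=C/c4ccc(O)c(OC)c4)c3)c(=O)[nH]2)cc1` differs from compound 3 at the other end of the molecule by 4-hydroxy-3-methoxyphenyl in place of 3,4,5-trimethoxyphenyl on a double-bonded chain carbon bound to a double-bonded chain carbon; in this assay compound 2 gives 2560 nM, and the step is a 1.5-fold lower number from compound 2 to compound 3 (0.18 log units; within the scatter). All three values sit close together, none separated from another beyond the scatter.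

Compound 4 `COc1cc(/C=C/C(=O)c2cccc(-n3cc(-c4ccc(Cl)cc4)[nH]c3=O)c2)ccc1O` is not yet measured. It carries the same change as compound 1, now on the core of compound 2: chloro in place of methoxy on an aromatic carbon. Since the earlier occurrence of this change gave only a 1.4-fold higher number from compound 3 to compound 1 (0.14 log units; within the scatter), a step of similar size is expected here, a 1.4-fold higher number from compound 2 to compound 4 (0.14 log units; within the scatter). Compound 4 is therefore estimated at 3500 nM in this assay, expected between 1500 nM and 8000 nM.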

Compound 4, concentration for 50% growth inhibition: 2280 nM
Estimate against measurement, compound 4: 1.5-fold (0.19 log units) above, and the stated range covers the measured number.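

The change from 4-methoxyphenyl to 4-chlorophenyl comes to a 1.1-fold lower number from compound 2 to compound 4 (0.05 log units; within the scatter) in this assay. Set beside the earlier step, it shows no difference between the two cores that can be told from the scatter: the same change on two cores in this assay, a 1.4-fold higher number (0.14 log units; within the scatter) from compound 3 to compound 1 and a 1.1-fold lower number (0.05 log units; within the scatter) from compound 2 to compound 4, 1.6-fold (0.19 log units) apart, within the scatter of two such steps. Among the compounds shown here, with both steps within the scatter, this shows only that the change leaves the number within the scatter on these two cores, and it does not show how the change would behave on any other core.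

Open, as far as these compounds go, is whether an amine or a carboxylic acid in place of the chloro would move the number beyond the scatter. Also open, from the compounds shown here alone, is whether the change carries over when a group other than 3,4,5-trimethoxyphenyl or 4-hydroxy-3-methoxyphenyl stands at the other end of the molecule.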